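The source may hold more compounds than are shown below. What is called first, only, known or untested is meant among the compounds shown, and "the series" means these compounds.

Measured so far:
Compound 1 `N#CNC(=N)NCCCn1nc(-c2ccccc2)ccc1=O`: > 100 mg/kg in a functional assay on the whole organism (stomach) with Rattus norvegicus as the target (on this read-out higher numbers stand for an effect only at larger amounts of compound and lower numbers for an effect already at smaller amounts), a limit.
Compound 2 `CCC/N=C(/NC#N)NCCCCCn1nc(-c2ccccc2)ccc1=O`: > 100 mg/kg, a limit.
Compound 3 `CC/N=C(/NC#N)NCCCCn1nc(-c2ccccc2)cc(C)c1=O`: 100 mg/kg.

Compound 1 stands only at a limit, (the limit of > 100 mg/kg in this assay, at which 2 of the 3 values shown sit), and gives no number. Compound 3 alone gives a number. Going by the values given here, no step between two measured compounds that differ in one place is available, so the size of a change in this assay cannot be read off the series. The move to compound 4 `C/N=C(/NC#N)NCCCn1nc(-c2ccccc2)ccc1=O` is a group of 6 heavy atoms (3 carbon, 3 nitrogen; no ring) in place of a group of 5 heavy atoms (2 carbon, 3 nitrogen; no ring), on an amine nitrogen. Compound 2 and compound 3 carry their own groups on the amine nitrogen and sit at the limit or at the same figure, giving no sign of an effect at smaller amounts. Compound 4 is expected to give 100 mg/kg, range 50 mg/kg to 300 mg/kg, most likely again only a limit. The expected step of a number no higher from compound 1 to compound 4 (the limit leaves the size open) is none beyond the scatter.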

Compound 4, dose for half-maximal effect: > 100 mg/kg
Compound 4: no number, only a limit; the forecaster's own chance of this, stated with the estimate: 70%; the middle value sits exactly at the limit.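

Compound 1 and compound 4 both stand only at a limit, so no step between them can be read: the limit of > 100 mg/kg in this assay, at which 3 of the 4 values shown sit.

The compounds shown leave open whether any group on the amine nitrogen gives an effect at smaller amounts of compound.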